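The source may report more compounds than this note shows. Statements on the series, on what has been measured and on what is new or still open speak of the compounds shown alone.

Measured compounds:
Compound 1, `COc1ccccc1S(=O)(=O)c1ccc(NC(=O)C(C)(O)C(F)(F)F)cc1`, gives 1600 nM in a functional assay (Cavia porcellus) with sulfonylurea receptors; K-ATP channels (Homo sapiens) as the target; a higher number here means a weaker inhibitor, a lower number a stronger inhibitor.
Compound 2, `COc1ccc(S(=O)(=O)c2ccc(NC(=O)C(C)(O)C(F)(F)F)cc2)cc1`, gives in this assay > 30000 nM, which is a limit of the assay and not a number.
Compound 3, `CC(O)(C(=O)Nc1ccc(S(=O)(=O)c2cncnc2)cc1)C(F)(F)F`, gives in this assay > 30000 nM, likewise a limit.

Compound 3 therefore stands at the limit of > 30000 nM in this assay, at which 2 of the 3 values shown sit; no number is known for it, only that it lies beyond the range the assay reports. Compound 4, `CC(O)(C(=O)Nc1ccc(S(=O)(=O)c2cnccn2)cc1)C(F)(F)F`, differs from it in one place: pyrazin-2-yl in place of pyrimidin-5-yl on a sulfonyl sulfur. Among the compounds with values here, two measured steps touch the pyrimidin-5-yl group that leaves. The step of an at least 18-fold higher number from compound 1 to compound 3 (1.27 log units; beyond the scatter) was large, and the step that the two limits leave unreadable from compound 2 to compound 3 cannot be sized because both ends sit at the limit. Neither step concerns a pyrazin-2-yl group, so nothing measured separates the two heteroaryl rings, and the reference point itself is a limit. The expected step is a step that the limit leaves unreadable from compound 3 to compound 4, judged to stay within the scatter. Compound 4 is thus estimated to give 40000 nM, with a range from 10000 nM to 150000 nM, most likely reported again as a limit.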

Compound 4, half-maximal inhibitory concentration: 12000 nM
Compound 4: the middle estimate sits 3.3-fold (0.52 log units) above what was measured; measured number inside the range.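

In this assay, the same ring atoms joined differently on the sulfonyl sulfur are enough to shift the result: pyrazin-2-yl in place of pyrimidin-5-yl gives an at least 2.5-fold lower number from compound 3 to compound 4 (0.39 log units; beyond the scatter). Pyrazin-2-yl can also be set against 4-methoxyphenyl, with an at least 2.5-fold lower number from compound 2 to compound 4 (0.39 log units; beyond the scatter), and compound 4 thereby becomes the first compound here without a 2-methoxyphenyl group to give a number rather than a limit. Even so, 2-methoxyphenyl remains the better group at this place, as pyrazin-2-yl gives a 7.5-fold higher number from compound 1 to compound 4 (0.88 log units; beyond the scatter).

From the compounds shown here alone, the true size of the steps from compound 2 and compound 3 stays open, as both compounds stand at a limit and not at a number: the limit of > 30000 nM in this assay, at which 2 of the 4 values shown sit. Also open, going by these compounds, is how a pyridin-2-yl ring or a 2-ethoxyphenyl group on the sulfonyl sulfur would compare with compound 1 and compound 4.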